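The source may hold more compounds than are shown below. What is called first, only, known or untested is meant among the compounds shown, and "the series" means these compounds.

Working notes on the series. In a functional assay, read by spectrophotometry, with a stated time of 5 min (a lower number here means a stronger inhibitor, a higher number a weaker inhibitor), compound 1 (`COc1cc(/C=C/C(=O)C(=Cc2ccc(OC)c(OC)c2)C(=O)/C=C/c2ccc(O)c(OC)c2)ccc1O`) gives 71000000 nM, compound 2 (`CCOc1ccc(C=C(C(=O)/C=C/c2ccc(O)c(OC)c2)C(=O)/C=C/c2ccc(O)c(OC)c2)cc1OCC`) gives 73000000 nM and compound 3 (`CCOc1cc(/C=C/C(=O)C(=Cc2ccc(O)c(OC)c2)C(=O)/C=C/c2ccc(O)c(OCC)c2)ccc1O`) gives 60500000 nM. These three values lie within the scatter of each other, so compound 3 stands level with the other two.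

Compound 4 (`CCOc1cc(/C=C/C(=O)C(=Cc2ccc(O)cc2)C(=O)/C=C/c2ccc(O)c(OCC)c2)ccc1O`) differs from compound 3 in one place: hydrogen in place of methoxy on an aromatic carbon. This is hydrogen in place of methoxy on an aromatic carbon, 4-hydroxy-3-methoxyphenyl to 4-hydroxyphenyl.

Among the measured compounds shown here, the only measured step is a 1.0-fold higher number from compound 1 to compound 2 (0.01 log units; within the scatter). It lies within the scatter but involves a different change, so it bears on this one only loosely. For the measured compounds named here, no measured pair shows the loss of a methoxy, so there is no direct precedent.

On the flat values of compound 1, compound 2 and compound 3, no shift beyond the scatter is expected in this assay, and no direction is favoured. The estimated step is a 1.1-fold higher number from compound 3 to compound 4 (0.03 log units; within the scatter). Compound 4 is estimated at 65000000 nM, with an expected range of 30000000 nM to 140000000 nM.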

Compound 4, half-maximal inhibitory concentration: 48000000 nM
Estimate against measurement, compound 4: 1.4-fold (0.13 log units) above, and the stated range covers the measured number.
By their numbers in this assay, from the lowest: compounds 4, 3, 1 and 2 (each within the scatter of the next).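

Hydrogen in place of methoxy on an aromatic carbon, ortho to a hydroxy group, gives a 1.3-fold lower number from compound 3 to compound 4 (0.10 log units; within the scatter) in this assay. The earlier compounds shown here held no pair with this change, and this one shows that 4-hydroxy-3-methoxyphenyl and 4-hydroxyphenyl cannot be told apart in this read-out, so the methoxy is not required to keep compound 4 level with compound 3. Nothing available accounts for this result.

The compounds shown carry only hydrogen or methoxy at this position, so it remains open whether a different group here, such as an amine or a carboxylic acid, would give a step beyond the scatter. Also open, going by these compounds, is whether the hydroxy group on the same ring can be replaced without such a step.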